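Thiophene for phenyl on the benzylic arm of compound 2

The source may report more compounds than this note shows. Statements on the series, on what has been measured and on what is new or still open speak of the compounds shown alone.

Compound 1 `CCSCCn1c(=O)n(CC)c(=O)c2[nH]c(-c3ccccc3)nc21`: 479 nM
Compound 2 `CCn1c(=O)c2c(nc(Cc3ccco3)n2C)n(Cc2ccccc2)c1=O`: 282 nM

In an assay on HEK293 cells for displacement of a labelled ligand from adenosine receptor A2b (Homo sapiens), read by scintillation counting (on this read-out lower numbers stand for stronger inhibition and higher numbers for weaker inhibition), compound 2 gives 282 nM and compound 1 gives 479 nM; the two lie within the usual scatter of each other, so neither stands apart. Compound 3 `CCn1c(=O)c2c(nc(Cc3ccco3)n2C)n(Cc2cccs2)c1=O` carries one change relative to compound 2: thiophen-2-yl in place of phenyl on a saturated chain carbon bound to an aromatic nitrogen. Among the measured compounds shown here, no pair of measured compounds shows this change, so it has no precedent here. The expectation is for no step beyond the scatter, estimated as a 1.1-fold lower number from compound 2 to compound 3 (0.04 log units; within the scatter). In this assay compound 3 is expected to give about 260 nM, within a range from 100 nM to 700 nM.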

Compound 3, inhibition constant: 26.9 nM
Estimate against measurement, compound 3: 9.7-fold (0.99 log units) above; measured number outside the range, below it.
By their numbers in this assay, from the lowest: compound 3; then compounds 2 and 1 (each within the scatter of the next).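

In this assay, thiophen-2-yl in place of phenyl on a saturated chain carbon bound to an aromatic nitrogen gives a 10-fold lower number from compound 2 to compound 3 (1.02 log units; beyond the scatter), so the read-out at this position depends strongly on which aromatic ring the chain carbon carries. Compound 1 differs from compound 2 in more than one place and could not show this. Nothing measured here explains the size of the step. The change is seen only once, on a single background. As far as these compounds go, it remains open whether thiophen-3-yl, pyridin-2-yl or a longer chain to the thiophene would give a similar number.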